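Swapping the Aryl Group on a Shared Orexin Antagonist Core

The source may hold more compounds than are shown below. What is called first, only, known or untested is meant among the compounds shown, and "the series" means these compounds.

Measured compounds:
compound 1, `CCn1nc(C)c2c1CCN([C@@H](C(=O)NC)c1ccccc1)[C@H]2CCc1ccc(C(F)(F)F)cc1`, giving 3 nM
compound 2, `CCn1nc(C)c2c1CCN(C(C(=O)NC)c1ccccc1)C2CCc1cccc(C(F)(F)F)c1`, giving 7 nM

In a functional assay on CHO cells for antagonist activity at Orexin receptor type 2 (Homo sapiens), read by FLIPR and calcium flux (a higher number here means a weaker inhibitor, a lower number a stronger inhibitor), compound 2 gives 7 nM, the higher of the two numbers; compound 1 gives 3 nM, and the gap between them lies beyond the scatter. Compound 3, `CCn1nc(C)c2c1CCN(C(C(=O)NC)c1ccccc1)C2CCc1ccc(Cl)cc1`, differs from compound 2 by 4-chlorophenyl in place of 3-(trifluoromethyl)phenyl on a saturated chain carbon, two bonds along the chain from a saturated ring carbon. Going by the values given here, no comparable step has been measured here, so the expected step of a 1.4-fold higher number from compound 2 to compound 3 (0.15 log units; within the scatter) is judged small, likely within the scatter and, if anything, toward a weaker inhibitor. Compound 3 is therefore estimated at 10 nM in this assay, within a range from 3 nM to 30 nM.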

Compound 3, half-maximal inhibitory concentration: 12 nM
For compound 3 the middle estimate is 1.2-fold (0.08 log units) below the measured one, within the range that was stated.
By their numbers in this assay, from the lowest: compound 1; then compounds 2 and 3 (each within the scatter of the next).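

In this assay, exchanging the 3-(trifluoromethyl)phenyl group for 4-chlorophenyl gives a 1.7-fold higher number from compound 2 to compound 3 (0.23 log units; within the scatter). At this position, the two substituted aryl groups therefore cannot be told apart in this assay, although they differ in substituent and heavy-atom count. No available measurement explains this result. On these data alone, whether an unsubstituted phenyl, a pyridine ring, or a cyclohexyl group would fit this position equally well remains open, as does the effect of a longer chain.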